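This account rests on a few compounds, and the source may have more. Where it says the series, first, only, none or still open, it means among the compounds named here.

In a functional assay on HCT-116 cells (Homo sapiens) for antiproliferative activity, read by CCK-8 assay, with a stated time of 72 h (on this read-out higher numbers stand for weaker inhibition and lower numbers for stronger inhibition), three compounds have been measured so far.

Compound 1 `Nc1ccccc1NC(=O)c1ccc(CNc2nc(Cl)nc3c2ncn3C2CCCC2)cc1` gives 850 nM
Compound 2 `Nc1ccccc1NC(=O)c1ccc(COCNc2nc(Nc3ccccc3)c3ncn(C4CCCC4)c3n2)cc1` gives 960 nM
Compound 3 `CCCCn1cnc2c(Nc3ccccc3)nc(NCOCc3ccc(C(=O)Nc4ccccc4N)cc3)nc21` gives 1190 nM

Compound 3, at 1190 nM, lies within the scatter of both compound 1 and compound 2, so the three values give no order. Compound 4 `CCCCn1cnc2c(Nc3cccc(Cl)c3)nc(NCOCc3ccc(C(=O)Nc4ccccc4N)cc3)nc21` differs from compound 3 by one change: chloro in place of hydrogen on an aromatic carbon. In other words, phenyl becomes 3-chlorophenyl. Going by the values given here, the only measured step between closely matched compounds is a 1.2-fold higher number from compound 2 to compound 3 (0.09 log units; within the scatter). It concerns butyl in place of cyclopentyl on an aromatic nitrogen, which is a different place in the structure, so it bears on the new change only indirectly. Among the compounds with values here, no measured step tests chloro in place of hydrogen at this position. With so little evidence, no step beyond the scatter is expected in this assay, and the uncertainty is wide. The expected step is a 1.2-fold lower number from compound 3 to compound 4 (0.08 log units; within the scatter). Compound 4 is estimated at 1000 nM, with an expected range from 400 nM to 2500 nM.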

Compound 4, half-maximal inhibitory concentration: 2120 nM
The estimate for compound 4 lay 2.1-fold (0.33 log units) below the measured number; the range from low to high includes it.
By their numbers in this assay, from the lowest: compounds 1, 2, 3 and 4 (each within the scatter of the next, the first and the last beyond it).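

In this assay, chloro in place of hydrogen on this aromatic carbon, the first change tested at this position, gives a 1.8-fold higher number from compound 3 to compound 4 (0.25 log units; within the scatter). The change from phenyl to 3-chlorophenyl, which adds one chlorine atom meta to a large group, therefore does not move the number beyond the usual scatter of this read-out, so the position accepts chloro without a clear gain or loss in this cell assay. No measurement at hand offers an explanation for the size of this step.

Going by these compounds, it remains open whether a different group on this same carbon, such as methoxy, an amine or a carboxylic acid, would give a step beyond the scatter. On these data alone, it also remains open whether chloro would give a similar step with cyclopentyl in place of butyl on the aromatic nitrogen.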